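Trading trifluoromethyl for hydroxy: what growth inhibition to expect

The source may report more compounds than this note shows. Statements on the series, on what has been measured and on what is new or still open speak of the compounds shown alone.

Measured in a functional assay on U-251 cells (Homo sapiens) for inhibition, read by sulforhodamine B assay, with a stated time of 48 h; on this read-out higher numbers stand for weaker inhibition of growth and lower numbers for stronger inhibition of growth:
- compound 1 `CC1(/C=C/c2ccccc2)C=CC(=O)O1`: 89800 nM
- compound 2 `CC1(/C=C/c2ccccc2C(F)(F)F)C=CC(=O)O1`: 14100 nM

Compound 2 has the lower of the two numbers, so it is the stronger growth inhibitor so far. Compound 3 `CC1(/C=C/c2ccccc2O)C=CC(=O)O1` differs from it as follows: hydroxy in place of trifluoromethyl on an aromatic carbon. In words, this is hydroxy in place of trifluoromethyl on an aromatic carbon. Among the measured compounds shown here, only one measured step bears on this: a 6.4-fold lower number from compound 1 to compound 2 (0.80 log units; beyond the scatter), where trifluoromethyl replaced hydrogen. For the measured compounds named here, no measured compound carries hydroxy, so the direction is uncertain, but part of that modest gain is expected to be lost in this assay. The expected step is a 2.1-fold higher number from compound 2 to compound 3 (0.33 log units; beyond the scatter). The estimate for compound 3 is 30000 nM, with an expected range of 8000 nM to 100000 nM.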

Compound 3, concentration for total growth inhibition: 70900 nM
The estimate for compound 3 lay 2.4-fold (0.37 log units) below the measured number; the range from low to high includes it.
By their numbers in this assay, from the lowest: compound 2; then compounds 3 and 1 (each within the scatter of the next).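

In this assay, hydroxy in place of trifluoromethyl on this aromatic carbon gives a 5.0-fold higher number from compound 2 to compound 3 (0.70 log units; beyond the scatter), while hydroxy in place of hydrogen gives a 1.3-fold lower number from compound 1 to compound 3 (0.10 log units; within the scatter). So among these compounds, the stronger growth inhibition at this position goes with trifluoromethyl alone, and a substituent here does not bring it by simply being present. Nothing shown gives a reason for this difference.

Going by these compounds, it remains open whether an amine, a methoxy group or a chlorine atom on this carbon would track compound 2 or compound 3. On these data alone, the effect of trifluoromethyl on other carbons of the aromatic ring is also open.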